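A few compounds are considered here, and "the series" means these few. Any claim that something is new, unique, unknown or untested is made for them only; others in the source may bear on it.

Of the compounds shown here, two have so far been measured in an assay on isolated protein for binding affinity to adenosine receptor A3 (Homo sapiens); on this read-out lower numbers stand for stronger inhibition and higher numbers for weaker inhibition. Compound 1 `CNC(=O)[C@H]1O[C@@H](n2cnc3c(NCc4cc(Cl)cc(Cl)c4)ncnc32)[C@H](O)[C@@H]1O` gives 2.5 nM. Compound 2 `CNC(=O)[C@H]1O[C@@H](n2cnc3c(NCc4cc(Cl)ccc4OCC(=O)O)ncnc32)[C@H](O)[C@@H]1N` gives 130 nM, the higher of the two numbers, and its gap to compound 1 lies beyond the scatter. Compound 3 `CNC(=O)[C@H]1O[C@@H](n2cnc3c(NCc4cc(Cl)ccc4OCC(=O)N4CCCCC4)ncnc32)[C@H](O)[C@@H]1N` differs from compound 2 in one place: piperidin-1-yl in place of hydroxy on a carbonyl carbon, which one bond further out reads carboxy to (piperidin-1-yl)carbonyl. For the measured compounds named here, no measured pair shows this change, so only a loose expectation is possible. The expected step is a 4.3-fold lower number from compound 2 to compound 3 (0.64 log units; beyond the scatter), toward a lower number. Compound 3 is estimated at 30 nM, with a range from 5 nM to 200 nM.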

Compound 3, inhibition constant: 18 nM
Compound 3: the middle estimate sits 1.7-fold (0.22 log units) above what was measured; measured number inside the range.
By their numbers in this assay, from the lowest: compound 1; then compound 3; then compound 2.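

In this assay, for the compounds shown here, the piperidin-1-yl group in place of hydroxy on the carbonyl carbon gives a 7.2-fold lower number from compound 2 to compound 3 (0.86 log units; beyond the scatter), the first step that can be read at a single position. It shows that this end of the side chain accepts a six-membered ring, and that the carboxy group is not required for a number in this range. Nothing measured here explains the step. Still open, from the compounds shown here alone, is whether the piperidine ring itself matters or whether a simpler amide, such as the methylamide or the morpholin-4-yl amide, would serve equally well.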